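Phenoxy in Place of Acetyl at the Cytotoxicity Limit

The source may report more compounds than this note shows. Statements on the series, on what has been measured and on what is new or still open speak of the compounds shown alone.

Compound 1 `CCOC(=O)CCCCCOc1cccc(CN(C(=O)c2ccc(-c3cccc(-c4ccccc4)c3)cc2)C(C)C)c1` and compound 2 `CCOC(=O)CCCCCOc1cccc(CN(C(=O)c2ccc(-c3cccc(C(C)=O)c3)cc2)C(C)C)c1` share one core and differ only in the group carried on an aromatic carbon. In an ADME assay on HEK293 cells (Homo sapiens) for cytotoxicity, read by CellTiter-Glo and resazurin assay, with a stated time of 72 h (a higher number here means that more compound is needed for the effect, a lower number that less compound is needed), compound 1 gives > 26000 nM, which is a limit of the assay rather than a number. In this assay compound 2 likewise gives > 26000 nM, again a limit. The step that the two limits leave unreadable from compound 1 to compound 2 therefore cannot be read, since both ends sit at the limit of > 26000 nM in this assay, at which 2 of the 2 values shown sit. Compound 2 thus stands at the limit in this assay, with no number of its own.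

Compound 3 `CCOC(=O)CCCCCOc1cccc(CN(C(=O)c2ccc(-c3cccc(Oc4ccccc4)c3)cc2)C(C)C)c1` differs from compound 2 by phenoxy in place of acetyl on an aromatic carbon. For the measured compounds named here, no measured step bears directly on this change, and the one step available, from phenyl to acetyl, was left unsized by the two limits. Going by the values given here, nothing among the measured compounds shows cytotoxicity within the readable range of this assay, so compound 3 is expected to remain at the limit as well, with a step of a number no higher from compound 2 to compound 3 (the limit leaves the size open) expected to lie within the scatter. Compound 3 is therefore estimated at 26000 nM, with a range from 10000 nM to 100000 nM.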

Compound 3, half-maximal effective concentration: > 19600 nM
Compound 3: no number, only a limit; the forecaster's own chance of this, stated with the estimate: 85%; the middle value does not contradict the limit.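

In this assay compound 3 gives > 19600 nM, which is a limit of the assay and not a number. The steps joining compound 3 to compound 1 and to compound 2 therefore cannot be read. The compounds shown leave open at what concentration any of the three would reach the effect in this assay, and whether phenyl, acetyl and phenoxy differ there at all.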